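Bromo for chloro at the assay limit

A few compounds are considered here, and "the series" means these few. Any claim that something is new, unique, unknown or untested is made for them only; others in the source may bear on it.

Compound 1 `COc1cc2occ(-c3csc4ccccc34)c(=O)c2cc1OC`: > 10000 nM
Compound 2 `O=C(/C=C/c1csc2ccccc12)c1cc(Br)cc(Br)c1O`: 4200 nM
Compound 3 `O=C(/C=C/c1cc2ccccc2s1)c1cc(Cl)ccc1O`: > 10000 nM

These three compounds were tested in a functional assay on A549 cells (Homo sapiens) for antiproliferative activity, read by sulforhodamine B assay, with a stated time of 72 h; a higher number here means a weaker inhibitor, a lower number a stronger inhibitor. Compound 3 reads > 10000 nM, which is a limit of the assay and not a number. Compound 1 reads > 10000 nM, which is also a limit. The set so far is marked by the limit of > 10000 nM in this assay, at which 2 of the 3 values shown sit, and compound 2 alone gives a number, 4200 nM.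

Compound 4 `O=C(/C=C/c1cc2ccccc2s1)c1cc(Br)ccc1O` differs from compound 3 in one place, with bromo in place of chloro on an aromatic carbon, para to a hydroxy group: bromo in place of chloro on an aromatic carbon. Going by the values given here, no measured step in the set shows what this exchange does, so no shift beyond the scatter is expected in this assay, in either direction. The estimate means a number no higher from compound 3 to compound 4 (the limit leaves the size open), and it is expected to leave the reading close to the limit. A reading reported only as a limit is the likeliest outcome. If a number is reported, the estimated value for compound 4 is 10000 nM, with an expected range from 5000 nM to 20000 nM.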

Compound 4, half-maximal inhibitory concentration: > 10000 nM
Compound 4: a limit, no number; the forecaster's own chance of this, stated with the estimate: 65%; the middle value sits exactly at the limit.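

Compound 3 and compound 4 both read only as limits and not as numbers, so no step between them can be read, and the set stays marked by that ceiling: the limit of > 10000 nM in this assay, at which 3 of the 4 values shown sit.

The compounds shown leave open whether bromo in place of chloro changes the antiproliferative activity at all.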